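Extending the sulfonyl methyl with a dimethylaminoethyl group

The source may hold more compounds than are shown below. What is called first, only, known or untested is meant among the compounds shown, and "the series" means these compounds.

Measured compounds:
compound 1 `CS(=O)(=O)c1ccc2sc(NC(=O)NC(=O)c3ccccc3Cl)nc2c1`: 3000 nM in a physicochemical assay for solubility, at pH 7.4; on this read-out higher numbers stand for higher solubility and lower numbers for lower solubility
compound 2 `CS(=O)(=O)c1ccc2nc(NC(=O)NC(=O)c3ccccc3Cl)sc2c1`: < 470 nM in this assay, a limit of the assay and not a number

Compound 1 and compound 2 share the same acylurea and sulfonyl-bearing core and differ only in how that core is joined. Compound 1 gives a numerical value in this assay. For compound 2 the assay reports only a limit, (the limit of < 470 nM in this assay, at which 1 of the 2 values shown sits), so where compound 2 truly stands in this assay is not known beyond that boundary.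

Compound 3 `CN(C)CCCS(=O)(=O)c1ccc2nc(NC(=O)NC(=O)c3ccccc3Cl)sc2c1` is not yet measured. It differs from compound 2 by 2-(dimethylamino)ethyl in place of hydrogen on a saturated chain carbon bound to a sulfonyl sulfur. Among the compounds with values here, no step between measured compounds matches this change, so its size cannot be read from the data at hand. The step from compound 2 to compound 3 is expected to be upward in this assay and larger than the usual scatter, estimated as an at least 10-fold higher number from compound 2 to compound 3 (1.02 log units; beyond the scatter). Compound 3 is expected to give 5000 nM in this assay, with a likely range from 800 nM to 40000 nM, though the starting point of compound 2 is itself only a limit.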

Compound 3, solubility: 240000 nM
Estimate against measurement, compound 3: 48-fold (1.68 log units) below, outside the stated range (above it).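

Compound 1 and compound 2 both carry the plain methylsulfonyl group, so neither could show how this place responds to change. With methylsulfonyl changed to (3-(dimethylamino)propyl)sulfonyl, this assay now reads an at least 510-fold higher number from compound 2 to compound 3 (2.70 log units; beyond the scatter), which shows that a single change on a saturated chain carbon bound to a sulfonyl sulfur can move this read-out by a large step, well beyond the usual scatter. In this assay compound 2 gives < 470 nM, which is a limit of the assay and not a number, so the step is known only as a lower bound on its size and its true size is not fixed: the limit of < 470 nM in this assay, at which 1 of the 3 values shown sits.

The compounds shown leave open whether the step follows the dimethylamino nitrogen or the longer chain alone, as a plain propyl chain, a hydroxypropyl chain or a chain ending in a carboxylic acid at the same place would begin to tell. They also leave open whether 2-(dimethylamino)ethyl would give a step of similar size on the differently joined core of compound 1, and whether a cyclic amine such as morpholine would serve in place of the dimethylamino group.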